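Swapping cyano for bromo: what to expect

A few compounds are considered here, and "the series" means these few. Any claim that something is new, unique, unknown or untested is made for them only; others in the source may bear on it.

- Compound 1 `COC(=O)C1=C(C)N=C(C)/C(=C(\O)OC)C1c1cccc(OC)c1`: 191 nM
- Compound 2 `COC(=O)C1=C(C)N=C(C)/C(=C(\O)OC)C1c1ccccc1I`: 46.8 nM
- Compound 3 `COC(=O)C1=C(C)N=C(C)/C(=C(\O)OC)C1c1ccccc1C#N`: 15.9 nM

In a functional assay (muscle tissue) with Cavia porcellus as the target (a lower number here means that less compound is needed, a higher number that more compound is needed for the effect), compound 3 has the lowest number of the three. Compound 4 `COC(=O)C1=C(C)N=C(C)/C(=C(\O)OC)C1c1ccccc1Br` carries bromo in place of cyano on an aromatic carbon. The nearest guide is compound 2, which also has a single atom at this place and leads to cyano through the modest 2.9-fold lower number from compound 2 to compound 3 (0.47 log units; beyond the scatter). The larger 4.1-fold lower number from compound 1 to compound 2 (0.61 log units; beyond the scatter) and a 12-fold lower number from compound 1 to compound 3 (1.08 log units; beyond the scatter) also alter the position of the group, so they bear on this change less directly. Removing cyano is therefore expected to give a modest rise in the number, estimated as a 1.9-fold higher number from compound 3 to compound 4 (0.28 log units; within the scatter). Compound 4 is estimated at 30 nM, with an expected range of 10 nM to 80 nM.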

Compound 4, half-maximal effective concentration: 7.59 nM
Beside the measured number, compound 4's estimate is 4.0-fold (0.60 log units) above it, outside the stated range (below it).
By their numbers in this assay, from the lowest: compound 4; then compound 3; then compound 2; then compound 1.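

At this place on the aromatic ring, bromo gives the lowest number of the four compounds, passing cyano by a modest but real margin (a 2.1-fold lower number from compound 3 to compound 4 (0.32 log units; beyond the scatter)). For the compounds shown here, the step between the two halogens is larger (a 6.2-fold lower number from compound 2 to compound 4 (0.79 log units; beyond the scatter)), so bromo and iodo are not interchangeable here, and the widest gap is the one to the 3-methoxyphenyl compound (a 25-fold lower number from compound 1 to compound 4 (1.40 log units; beyond the scatter)). No measurement shown explains these differences. Going by these compounds, whether chloro or fluoro at this place would lower the number further remains open, as does how an amine or a carboxylic acid there would behave.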